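Swapping the Benzyl Group on a Cytotoxicity Scaffold

The compounds below may be only part of what the source reports. "The series", "measured", "known", "first", "only" and "open" are said of these compounds alone.

Going by the values given here, compound 1 `COC(=O)c1ccc(NCc2cncn2Cc2ccc(Cl)cc2)cc1-c1ccccc1` is the only member of this set with an actual number in a toxicity assay on NIH3T3 cells (Mus musculus) for cytotoxicity, read by resazurin assay; a higher number here means that more compound is needed for the effect, a lower number that less compound is needed: compound 1 gives 25000 nM. Compound 2 `Clc1ccc(Cn2cncc2CNc2ccc(-c3nc4ccccc4s3)c(-c3ccccc3)c2)cc1` reaches only a limit of the assay, > 1000 nM. Compound 3 `CC(C)OC(=O)c1ccc(NCc2cncn2Cc2ccc(-c3ccccc3)cc2)cc1-c1ccccc1` likewise reaches only a limit, > 10000 nM. Among the compounds with values here, the single step joining two measured compounds, a step that the limit leaves unreadable from compound 1 to compound 2, cannot be sized. This is so because compound 2 sits at the limit of > 1000 nM in this assay, at which 1 of the 3 values shown sits. Compound 4 `COC(=O)c1ccc(NCc2cncn2Cc2ccccc2C#N)cc1-c1ccccc1` differs from compound 1 in one place: 2-cyanophenyl in place of 4-chlorophenyl on a saturated chain carbon bound to an aromatic nitrogen. Within the data shown here, no measured step touches this part of the molecule, so no change beyond the scatter is expected. Compound 4 is therefore estimated at 25000 nM, between 10000 nM and 60000 nM, an expected step of no change at the digits printed from compound 1 to compound 4 (within the scatter).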

Compound 4, half-maximal effective concentration: 25000 nM
Compound 4: the middle estimate sits on the measured number at the digits printed; the range from low to high includes it.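

The earlier compounds shown here gave no readable step at this position, and now there is one: in this assay, changing 4-chlorobenzyl to 2-cyanobenzyl gives no change at the digits printed from compound 1 to compound 4 (within the scatter), although the entering group carries a triple bond and a hydrogen-bond acceptor that the leaving group lacks. At this place, then, the two groups give the same reading on the shared core. No measurement shown gives a reason for this result.

One pair cannot show how far this holds. A benzyl ring carrying an amine or a carboxylic acid, or a longer chain at this place, could read differently.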